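A few compounds are considered here, and "the series" means these few. Any claim that something is new, unique, unknown or untested is made for them only; others in the source may bear on it.

Measured compounds in a functional assay (Homo sapiens) for inhibition of Nucleic Acid, tested at 100 uM; a lower number here means less inhibition, a higher number more inhibition at the concentration tested (going by the name of the read-out):
- compound 1, `OC[C@H]1O[C@@H](n2cnc3c(NCc4ccccc4)nccc32)C[C@@H]1O`: 15%
- compound 2, `OCCNc1nccc2c1ncn2C1O[C@H](CO)[C@@H](O)[C@H]1O`: 0%
- compound 3, `[O-][n+]1ccc2c(c1)ncn2C1O[C@H](CO)[C@@H](O)[C@H]1O`: 5%

Of the compounds shown here, three have been examined in this assay so far. Compound 1 gives 15%, the highest of the three numbers. Compound 3 gives 5%, which lies within the usual scatter of the number for compound 1, so the two cannot be told apart. Compound 2 gives 0%, and its gap to compound 1 is beyond the scatter.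

The next compound, compound 4 with the structure `OC[C@H]1O[C@@H](n2cnc3cnccc32)C[C@@H]1O`, is not yet measured. It differs from compound 1 in one place: hydrogen in place of benzylamino on an aromatic carbon. For the measured compounds named here, no step between two measured compounds isolates this change, so the effect is unknown. Since the benzylamino group leaves and only a hydrogen enters, and the other two compounds sit at or below the level of compound 1, a small downward step or none beyond the scatter is expected. Compound 4 is therefore expected to give 5%, in a range from -10% to 20%. This corresponds to an expected step of a number 10 percentage points lower from compound 1 to compound 4 (within the scatter).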

Compound 4, a percentage reported as inhibition, at one concentration (the size of the read-out at that concentration, not a potency): 6%
Compound 4: the middle estimate sits 1 percentage points below what was measured; the measured number falls inside the stated range.
By their numbers in this assay, from the lowest: compounds 2, 3, 4 and 1 (each within the scatter of the next, the first and the last beyond it).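

For the compounds shown here, compounds 1 and 4 give the first direct reading of this position: in this assay, putting hydrogen in place of benzylamino, on the aromatic carbon next to the ring nitrogen, gives a number 9 percentage points lower from compound 1 to compound 4 (within the scatter) and so does not separate the two compounds. Within this pair, the read-out therefore shows no clear dependence on the benzylamino group, even though the change removes 8 heavy atoms and an entire six-membered aromatic ring. Nothing in the data gives a reason for this step.

What the compounds shown leave open is how other groups on this same carbon would read, such as a small methylamino group, a longer phenylethylamino chain or a carboxylic acid. They also leave open whether any of these would produce a step beyond the scatter from compound 4.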